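From Diethylamino to Tert-Butyl on the Shared Core

This account rests on a few compounds, and the source may have more. Where it says the series, first, only, none or still open, it means among the compounds named here.

The series rests on a shared core carrying a substituted phenyl ring. Compound 1 `CN(C)c1ccc(N2C(=O)NC3(CSC4=C3C(=O)c3ncccc3C4=O)C2=O)cc1` bears a dimethylamino group and in a functional assay on CCRF-SB cells (Homo sapiens) for antiproliferative activity, read by MTT assay, with a stated time of 96 h (on this read-out higher numbers stand for weaker inhibition and lower numbers for stronger inhibition), compound 1 gives 1 nM. Among the compounds with values here, compound 2 `CCN(CC)c1ccc(N2C(=O)NC3(CSC4=C3C(=O)c3ncccc3C4=O)C2=O)cc1` carries diethylamino in its place; in this assay compound 2 gives 9 nM, the highest of the two numbers measured so far, the only step being a 9.0-fold higher number from compound 1 to compound 2 (0.95 log units; beyond the scatter).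

Compound 3 `CC(C)(C)c1ccc(N2C(=O)NC3(CSC4=C3C(=O)c3ncccc3C4=O)C2=O)cc1` is the next member. Relative to compound 2 the change is tert-butyl in place of diethylamino on an aromatic carbon. Within the data shown here, the single measured step bears on it only loosely: it shows that enlarging the group para to a large group, from dimethylamino to diethylamino, raised the number modestly, while the present change keeps a similar bulk but removes the hydrogen-bond acceptor. Among the measured compounds shown here, with no closer precedent, the account expects at most a small further rise in this assay, most likely within the scatter, so the expected step is a 1.7-fold higher number from compound 2 to compound 3 (0.22 log units; within the scatter). For compound 3 the estimated value in this assay is 15 nM, with a plausible range from 3 nM to 80 nM.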

Compound 3, half-maximal inhibitory concentration: 200 nM
Estimate against measurement, compound 3: 13-fold (1.12 log units) below, outside the stated range (above it).
By their numbers in this assay, from the lowest: compound 1; then compound 2; then compound 3.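

In this assay, tert-butyl in place of diethylamino on this aromatic carbon brings a 22-fold higher number from compound 2 to compound 3 (1.35 log units; beyond the scatter), and the same group in place of dimethylamino brings a 200-fold higher number from compound 1 to compound 3 (2.30 log units; beyond the scatter). Both steps are larger than the one between the two amino groups, a 9.0-fold higher number from compound 1 to compound 2 (0.95 log units; beyond the scatter), so this position separates an all-carbon group from the two nitrogen-bearing groups more sharply than it separates those two from each other. The number also does not follow heavy-atom count across the three compounds: the ranking from dimethylamino to diethylamino would suggest that a bigger group gives a higher number, yet compound 3 goes against this, since tert-butyl has fewer heavy atoms than diethylamino and still gives the highest number of the three; nothing available explains the rise.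

The compounds shown leave open whether the nitrogen itself or some other feature of the amino groups sets the difference, a question that a methoxy group or an isopropyl group at this place could address. They also leave open how a cyclic amine such as pyrrolidine or morpholine, or a plain primary amine, would compare with the two dialkylamino groups.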